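Chloro to Fluoro on the Benzyl Ring

A few compounds are considered here, and "the series" means these few. Any claim that something is new, unique, unknown or untested is made for them only; others in the source may bear on it.

Measured compounds:
compound 1 `O=C(O)c1nn(Cc2cc(Br)ccc2OCc2ccccc2)cc1F` — 692 nM
compound 2 `O=C(O)c1nn(Cc2cc(Br)ccc2OCc2ccccc2)cc1Cl` — < 2000 nM (a limit of the assay)
compound 3 `Cc1cc(C(=O)O)nn1Cc1cc(Br)ccc1OCc1ccc(Cl)cc1` — 8.71 nM

In a functional assay on CHO-K1 cells for antagonist activity at prostaglandin E2 receptor EP1 subtype (Homo sapiens), read by FLIPR (on this read-out higher numbers stand for weaker inhibition and lower numbers for stronger inhibition), compound 1 gives 692 nM. Compound 2 reaches only a limit of the assay, < 2000 nM. The change fluoro in place of chloro on an aromatic carbon gives a step that the limit leaves unreadable from compound 2 to compound 1, and its size stays hidden because of the limit of < 2000 nM in this assay, at which 1 of the 3 values shown sits. Compound 3 gives 8.71 nM, the lowest of the two numbers and far from compound 1; how the core of compound 3 differs from the core of compound 2 is not broken down here.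

Compound 4 `Cc1cc(C(=O)O)nn1Cc1cc(Br)ccc1OCc1ccc(F)cc1` is compound 3 with fluoro in place of chloro on an aromatic carbon. This is the same kind of change as from compound 2 to compound 1, but the place differs: there it sat on a five-membered aromatic ring with 2 nitrogen, next to the ring atom that bears a carboxy group; here it sits on a six-membered aromatic ring of carbon only, para to a large group. The measured step gives no size, so the expectation rests on compound 3's own value 8.71 nM. Compound 4 is expected to show a step of a 2.3-fold higher number from compound 3 to compound 4 (0.36 log units; beyond the scatter). Compound 4 is thus estimated at 20 nM, likely between 6 nM and 60 nM.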

Compound 4, inhibition constant: 11.8 nM
Estimate against measurement, compound 4: 1.7-fold (0.23 log units) above; the measured number falls inside the stated range.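

On the core of compound 3, in this assay, swapping the 4-chlorobenzyl group for the 4-fluorobenzyl group gives a 1.4-fold higher number from compound 3 to compound 4 (0.13 log units; within the scatter), so on this core the two halogens cannot be told apart at this position. Going by these compounds, the same swap on the core of compound 1 cannot be read, and the size of that step stays unknown because compound 2 gives only a limit of the assay, not a number: the limit of < 2000 nM in this assay, at which 1 of the 4 values shown sits. The series therefore offers a single readable step for this change, on a six-membered aromatic ring of carbon only, and one step cannot show whether the result carries over to another core.

The compounds shown leave open how a methoxy or a nitrile group would read in this assay if it took the place of the chloro on compound 3. They also leave open what would happen if an amide replaced the carboxylic acid that all of these compounds share.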